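The source may report more compounds than this note shows. Statements on the series, on what has been measured and on what is new or still open speak of the compounds shown alone.

Among the measured compounds shown here, in a functional assay on T47D cells (Homo sapiens) for antiproliferative activity, read by MTT assay, with a stated time of 72 h (a lower number here means a stronger inhibitor, a higher number a weaker inhibitor), compound 3 (`COc1cccc(-n2ccnc2-c2cc(OC)c(OC)c(OC)c2)c1`) gives 32200 nM, the only actual number in this small set. Compound 1 (`CCn1ccnc1-c1cc(OC)c(OC)c(OC)c1`) reads > 100000 nM, which is a limit of the assay. Compound 2 (`COc1cc(-c2nccn2CC(C)C)cc(OC)c1OC`) reads > 100000 nM, also a limit.

The next compound, compound 4 (`COc1cc(-c2nccn2-c2ccc(Br)cc2)cc(OC)c1OC`), has 4-bromophenyl in place of 3-methoxyphenyl on an aromatic nitrogen. For the measured compounds named here, two measured steps touch that same nitrogen: an at least 3.1-fold lower number from compound 1 to compound 3 (0.49 log units; beyond the scatter) and an at least 3.1-fold lower number from compound 2 to compound 3 (0.49 log units; beyond the scatter). Both are modest at minimum, and both put the ring on the nitrogen in place of a saturated chain. Neither swaps one ring for another, so they say little directly about this change. Compound 4 keeps a six-membered aromatic ring there, so the gain seen in those steps should largely remain, and compound 3 at 32200 nM is the natural anchor. Going by the values given here, no step clearly beyond the scatter is therefore expected in this assay, though a slightly lower number seems likelier than a higher one. The expected step is a 1.8-fold lower number from compound 3 to compound 4 (0.25 log units; within the scatter). For compound 4 the estimated value is 18000 nM, with an expected range of 2500 nM to 80000 nM.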

Compound 4, half-maximal inhibitory concentration: 24600 nM
Beside the measured number, compound 4's estimate is 1.4-fold (0.14 log units) below it, and the stated range covers the measured number.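

In this assay, among the compounds shown here, an aromatic ring on the nitrogen is replaced here for the first time by a different aromatic ring, giving a 1.3-fold lower number from compound 3 to compound 4 (0.12 log units; within the scatter), so 4-bromophenyl and 3-methoxyphenyl read alike in this pair. The gain over a saturated chain also appears without the 3-methoxyphenyl group, as an at least 4.0-fold lower number from compound 2 to compound 4 (0.60 log units; beyond the scatter) and an at least 4.0-fold lower number from compound 1 to compound 4 (0.60 log units; beyond the scatter) show. Compound 1 and compound 2 each stand at a limit rather than a number, so these two steps give only a minimum: the limit of > 100000 nM in this assay, at which 2 of the 4 values shown sit.

The pair changes both the group on the ring and its place, so 3-methoxyphenyl and 4-bromophenyl cannot separate those two effects. On these data alone, what an unsubstituted phenyl, or a phenyl carrying an amine or a carboxylic acid, would give on that nitrogen remains open.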